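Methyl Branch on a Shared Core: Cytotoxicity Outlook

The compounds below may be only part of what the source reports. "The series", "measured", "known", "first", "only" and "open" are said of these compounds alone.

Compound 1 `COc1ccc(CSc2nc(Cc3cc(C)cc(C)c3)c(C)c(=O)[nH]2)cc1` and compound 2 `CCc1c(Cc2cc(C)cc(C)c2)nc(SCc2ccc(OC)cc2)[nH]c1=O` share a core with compound 3 `CCc1c(Cc2cccc3ccccc23)nc(SCc2ccc(OC)cc2)[nH]c1=O`; how the core of compound 1 differs from that of compound 3 is not broken down here. In an ADME assay on MT4 cells (Homo sapiens) for cytotoxicity, read by MTT assay (on this read-out lower numbers stand for higher toxicity in this test and higher numbers for lower toxicity in this test), compound 1 reaches only a limit, > 329000 nM. Compound 2 likewise reaches only a limit in this assay, > 317000 nM. Compound 3 gives 261000 nM in this assay. The step that the two limits leave unreadable from compound 1 to compound 2 came with the change (methyl in place of hydrogen on a saturated chain carbon bound to an aromatic carbon). The step of an at least 1.2-fold lower number from compound 2 to compound 3 (0.08 log units; that floor lies within the scatter) followed. Compound 4 `COc1ccc(CSc2nc(Cc3cccc4ccccc34)c(C(C)C)c(=O)[nH]2)cc1` differs from compound 3 by methyl in place of hydrogen on a saturated chain carbon bound to an aromatic carbon and a saturated chain carbon; this is the same kind of change as from compound 1 to compound 2, but here the saturated chain carbon is bound to an aromatic carbon and a saturated chain carbon, not to an aromatic carbon alone. The expected step is a 1.0-fold lower number from compound 3 to compound 4 (0.02 log units; within the scatter). That expectation rests on compound 3 at 261000 nM and on the earlier step that the two limits leave unreadable from compound 1 to compound 2. Compound 4 is expected to give about 250000 nM, between 120000 nM and 400000 nM.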

Compound 4, half-maximal cytotoxic concentration: 37400 nM
The estimate for compound 4 lay 6.7-fold (0.83 log units) above the measured number; measured number outside the range, below it.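

In this assay, the change from ethyl to isopropyl on the core of compound 3 gives a 7.0-fold lower number from compound 3 to compound 4 (0.84 log units; beyond the scatter), which means higher toxicity in this test. Compound 2 reaches only a limit of the assay, not a number: the limit of > 317000 nM in this assay, at which 1 of the 4 values shown sits. The related step from compound 1 to compound 2 cannot be read, as both compounds give only limits, so the data do not show whether this kind of change carries from one core to another.

The compounds shown leave open whether isopropyl would give a similar step with 3,5-dimethylphenyl in place of naphthalen-1-yl. They also leave open how a longer chain or an amine in place of isopropyl would read in this assay.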